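Hydroxy for Fluoro on the Aryl Alkyne of Compound 1

The source may report more compounds than this note shows. Statements on the series, on what has been measured and on what is new or still open speak of the compounds shown alone.

Of the compounds shown here, three sharing one core have been tested in an assay on 1321N1 cells for antagonist activity at P2Y purinoceptor 6 (Homo sapiens), read by FLIPR and calcium flux; on this read-out lower numbers stand for stronger inhibition and higher numbers for weaker inhibition. Compound 1 `O=[N+]([O-])C1=Cc2cc(C#Cc3ccc(F)cc3)ccc2OC1C(F)(F)F` carries a 4-fluorophenyl group on an alkyne and gives 8860 nM, the highest of the three numbers. Compound 2 `O=[N+]([O-])C1=Cc2cc(F)ccc2OC1C(F)(F)F`, which has a fluoro directly on the core, gives 1150 nM, and compound 3 `CC[Si](C#Cc1cccc2c1OC(C(F)(F)F)C([N+](=O)[O-])=C2)(CC)CC`, which carries a triethylsilyl group on an alkyne, gives 461 nM. Both of these gaps to compound 1 lie beyond the scatter of repeated measurements, so compound 1 stands as the weakest inhibitor of the three on this read-out.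

The next compound, compound 4 `O=[N+]([O-])C1=Cc2cc(C#Cc3ccc(O)cc3)ccc2OC1C(F)(F)F`, keeps the aryl alkyne of compound 1 and changes only its terminal substituent: hydroxy in place of fluoro on an aromatic carbon. Going by the values given here, no measured pair in this set shows what such an exchange does, so any expectation rests on the structural change alone. A single hydroxy for a fluoro is a small change, and a step within or only modestly beyond the scatter, in either direction, seems the most likely outcome.

On that basis compound 4 is expected to give about 6000 nM in this assay, within a range of 1500 nM to 25000 nM, which corresponds to an estimated 1.5-fold lower number from compound 1 to compound 4 (0.17 log units; within the scatter).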

Compound 4, half-maximal inhibitory concentration: 5360 nM
The estimate for compound 4 lay 1.1-fold (0.05 log units) above the measured number; measured number inside the range.
By their numbers in this assay, from the lowest: compound 3; then compound 2; then compounds 4 and 1 (each within the scatter of the next).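

In this assay, going by these compounds alone, hydroxy in place of fluoro on the aromatic carbon para to a large group gives a 1.7-fold lower number from compound 1 to compound 4 (0.22 log units; within the scatter), and this is the first pair in the set that differs in one place, so it gives the first direct reading of any change on the aryl alkyne. At this position, the 4-fluorophenyl to 4-hydroxyphenyl exchange brings in a hydrogen-bond donor and a hydrogen-bond acceptor that the fluoro does not have, yet the two numbers stay within the scatter of each other, and the read-out does not separate the two groups. No measurement at hand bears on the reason for this result.

A single exchange at one carbon says nothing about how an amine, a methoxy group or a carboxylic acid would read at the same place on the ring. On these data alone, compounds 2 and 3 differ from compound 1 in more than one place, so what the aryl alkyne itself contributes, and whether a longer chain between the alkyne and the ring would alter the picture, remain open.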